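Compound 2 to compound 3: 2,4-dichlorophenyl for 4-hydroxyphenyl

A few compounds are considered here, and "the series" means these few. Any claim that something is new, unique, unknown or untested is made for them only; others in the source may bear on it.

Of the compounds shown here, two sharing one core have been measured in a functional assay on SW-620 cells (Homo sapiens); on this read-out higher numbers stand for weaker inhibition of growth and lower numbers for stronger inhibition of growth. Compound 1 (`O=S(=O)(/C=C/c1ccc(Br)cc1)Cc1ccc(Nc2ncnc3ccc(Br)cc23)cc1`) gives > 100000 nM, and this figure is a limit of the assay.

Going by the values given here, compound 2 (`O=S(=O)(/C=C/c1ccc(O)cc1)Cc1ccc(Nc2ncnc3ccc(Br)cc23)cc1`) gives 94000 nM, the only actual number so far, so its standing can be read only against the figure for compound 1. Among the compounds with values here, the one measured step, an at least 1.0-fold lower number from compound 1 to compound 2 (0.02 log units; that floor lies within the scatter), is hydroxy in place of bromo on an aromatic carbon, and it does not go beyond the scatter.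

Compound 3 (`O=S(=O)(/C=C/c1ccc(Cl)cc1Cl)Cc1ccc(Nc2ncnc3ccc(Br)cc23)cc1`) differs from compound 2 as follows: 2,4-dichlorophenyl in place of 4-hydroxyphenyl on a double-bonded chain carbon bound to a double-bonded chain carbon. This places 2,4-dichlorophenyl in place of 4-hydroxyphenyl on a double-bonded chain carbon bound to a double-bonded chain carbon.

Within the data shown here, the measured step is the only guide, and it also concerns a hydroxy group and a halogen on that ring. No change beyond the scatter is therefore expected in this assay, in either direction. The estimated move is a 1.0-fold lower number from compound 2 to compound 3 (0.02 log units; within the scatter), and a report of only a limit is also quite possible. For compound 3 the expected value is 90000 nM, with an estimated range of 30000 nM to 200000 nM.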

Compound 3, concentration for 50% growth inhibition: > 100000 nM
Compound 3 ended at the assay's limit (the forecaster's own chance of this, stated with the estimate: 50%); middle value at least 1.1-fold (0.04 log units) away from the limit.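

In this assay compound 3 gives > 100000 nM, which is a limit of the assay and not a number. The change from 4-hydroxyphenyl to 2,4-dichlorophenyl on a double-bonded chain carbon bound to a double-bonded chain carbon is read as an at least 1.0-fold higher number from compound 2 to compound 3 (0.02 log units; that floor lies within the scatter), so a ring with two chlorines and no hydrogen-bond donor adds a second halogen-bearing case to compound 1, and among the three compounds shown, a real number remains confined to compound 2, though no step shown goes beyond the scatter. The step between the two limits cannot be read, and this position can be ranked no further in this assay because the values crowd at one ceiling: the limit of > 100000 nM in this assay, at which 2 of the 3 values shown sit.

Open, as far as these compounds go, is whether an amine or a carboxylic acid on this ring, or a longer chain in place of the 2-(4-hydroxyphenyl)ethenyl group, would move the value in this assay clearly away from that limit. Also open, from the compounds shown here alone, is whether any change on the shared core, away from this position, would bring the series into a range where steps at this position can be sized.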